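The source may report more compounds than this note shows. Statements on the series, on what has been measured and on what is new or still open speak of the compounds shown alone.

Compound 1 `COc1cc2c(Oc3ccc(NC(=O)c4nn(-c5ccccc5)c(=O)c5ccccc45)cc3F)ccnc2cc1OCCCN1CCN(C)CC1` gives 620 nM in a functional assay on MKN-45 cells (Homo sapiens) for cytotoxicity, read by MTT assay, with a stated time of 72 h; on this read-out higher numbers stand for weaker inhibition and lower numbers for stronger inhibition. Compound 2 `COc1cc2c(Oc3ccc(NC(=O)c4nn(-c5ccccc5F)c(=O)c5ccccc45)cc3F)ccnc2cc1OCCCN1CCN(C)CC1` gives 210 nM in this assay, and the step of a 3.0-fold lower number from compound 1 to compound 2 (0.47 log units; beyond the scatter) leaves compound 2 with the lowest of the two numbers. Compound 3 `COc1cc2c(Oc3ccc(NC(=O)c4nn(-c5ccc([N+](=O)[O-])cc5)c(=O)c5ccccc45)cc3F)ccnc2cc1OCCCN1CCN(C)CC1` differs from compound 2 by 4-nitrophenyl in place of 2-fluorophenyl on an aromatic nitrogen. Among the measured compounds shown here, the only measured step concerns adding a fluorine to that phenyl ring, not exchanging the fluorophenyl for a nitrophenyl, so it gives little direct guidance; a modest change in either direction is the most that can be expected. Compound 3 is therefore estimated at 400 nM, with a range from 150 nM to 1200 nM. This corresponds to an expected step of a 1.9-fold higher number from compound 2 to compound 3 (0.28 log units; within the scatter).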

Compound 3, half-maximal inhibitory concentration: 1320 nM
Compound 3: the middle estimate sits 3.3-fold (0.52 log units) below what was measured, outside the stated range (above it).
By their numbers in this assay, from the lowest: compound 2; then compound 1; then compound 3.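

On the phenyl ring carried by the aromatic nitrogen, substituents can move the number in either direction. In this assay, 4-nitrophenyl in place of 2-fluorophenyl gives a 6.3-fold higher number from compound 2 to compound 3 (0.80 log units; beyond the scatter), and nitro in place of hydrogen gives a 2.1-fold higher number from compound 1 to compound 3 (0.33 log units; beyond the scatter), so a substituent on this ring does not by itself lower the number. Nothing available here gives a reason for this.

Fluoro and nitro differ in both identity and ring place, so the compounds shown cannot separate these two changes. Going by these compounds, how 4-fluorophenyl or 2-nitrophenyl would compare remains open.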